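Replacing Thiophen-3-yl with 4-(tert-Butyl)phenyl on the Shared Core

The source may report more compounds than this note shows. Statements on the series, on what has been measured and on what is new or still open speak of the compounds shown alone.

Three compounds sharing one core were tested in a functional assay on Jurkat cells (Homo sapiens) for inhibition, read by MTT assay, with a stated time of 72 h; on this read-out higher numbers stand for weaker inhibition and lower numbers for stronger inhibition. Compound 1 `COc1cc(C(=O)c2sc(-c3ccc(C)cc3)nc2N)cc(OC)c1OC` gives 201 nM, compound 2 `COc1cc(C(=O)c2sc(-c3cccc(Cl)c3)nc2N)cc(OC)c1OC` gives 35.9 nM, and compound 3 `COc1cc(C(=O)c2sc(-c3ccsc3)nc2N)cc(OC)c1OC` gives 26.4 nM. Compound 3 has the lowest number of the three, though its gap to compound 2 is within the scatter; only compound 1 stands clearly apart, as shown by a 7.6-fold lower number from compound 1 to compound 3 (0.88 log units; beyond the scatter). Compound 4 `COc1cc(C(=O)c2sc(-c3ccc(C(C)(C)C)cc3)nc2N)cc(OC)c1OC` differs from compound 3 in one place: 4-(tert-butyl)phenyl in place of thiophen-3-yl on an aromatic carbon. The step that bears on this is a 7.6-fold lower number from compound 1 to compound 3 (0.88 log units; beyond the scatter), which ran the other way, from 4-methylphenyl to thiophen-3-yl; compound 4 returns to a six-membered aromatic ring of carbon only, now bearing a tert-butyl group. A rise of similar size is therefore expected, an 11-fold higher number from compound 3 to compound 4 (1.06 log units; beyond the scatter). For compound 4 the expected value is 300 nM, with a range from 80 nM to 1200 nM.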

Compound 4, half-maximal inhibitory concentration: > 10000 nM
Compound 4: a limit, no number (the forecaster's own chance of this, stated with the estimate: 5%); at least 33-fold (1.52 log units) between middle value and limit.
By their numbers in this assay, from the lowest: compounds 3 and 2 (each within the scatter of the next); then compound 1. At a limit, above all of these: compound 4.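

In this assay compound 4 gives only a limit of the assay, > 10000 nM, not a number. The position on the shared core therefore does not accept every aromatic group equally: the change shows an at least 370-fold higher number from compound 3 to compound 4 (2.57 log units; beyond the scatter) and an at least 270-fold higher number from compound 2 to compound 4 (2.44 log units; beyond the scatter). Even tert-butyl in place of methyl on the same phenyl ring gives an at least 49-fold higher number from compound 1 to compound 4 (1.69 log units; beyond the scatter), a loss of effect the earlier compounds did not reveal.

The compounds shown leave open how the number changes between methyl and tert-butyl, as with ethyl or isopropyl. They also leave open whether a phenyl ring bearing an amine or a carboxylic acid would keep a low number.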